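The compounds below may be only part of what the source reports. "The series", "measured", "known", "first", "only" and "open" are said of these compounds alone.

Compound 1 `[O-][n+]1nc(NCCN2CCCCC2)[n+]([O-])c2cc(Cl)ccc21` and compound 2 `CCCN(CCC)CCNc1n[n+]([O-])c2ccc(Cl)cc2[n+]1[O-]` share a core and differ in a single place, (dipropylamino in place of piperidin-1-yl on a saturated chain carbon, two bonds along the chain from a nitrogen on an aromatic ring). In a functional assay on HT-29 cells (Homo sapiens) for cytotoxicity, with a stated time of 4 h (a lower number here means a stronger inhibitor, a higher number a weaker inhibitor), compound 1 gives 400 nM, and compound 2 gives 600 nM; the step of a 1.5-fold higher number from compound 1 to compound 2 (0.18 log units; within the scatter) lies within the usual scatter of repeated measurements. Compound 3 `CC(C)c1ccc2c(c1)[n+]([O-])c(NCCN1CCCCC1)n[n+]2[O-]` keeps the piperidin-1-yl group of compound 1 but differs from it in the core, (isopropyl in place of chloro on an aromatic carbon). In this assay compound 3 gives 2700 nM, and the step of a 6.8-fold higher number from compound 1 to compound 3 (0.83 log units; beyond the scatter) is beyond the scatter, so compound 3 stands with the highest of the three numbers.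

Compound 4 `CCCN(CCC)CCNc1n[n+]([O-])c2ccc(C(C)C)cc2[n+]1[O-]` has not yet been measured. It differs from compound 3 in one place, (dipropylamino in place of piperidin-1-yl on a saturated chain carbon, two bonds along the chain from a nitrogen on an aromatic ring). For the measured compounds named here, this is the same change as the one from compound 1 to compound 2, made at the same place on the chain; the two cores differ in the way already described for compound 1 and compound 3. Because the step of a 1.5-fold higher number from compound 1 to compound 2 (0.18 log units; within the scatter) lay within the scatter, the corresponding step for compound 4 is expected to be of similar size, a 1.5-fold higher number from compound 3 to compound 4 (0.17 log units; within the scatter). That expectation rests on one measured pair only, so the range is kept wide. Compound 4 is therefore expected to give about 4000 nM in this assay, between 1800 nM and 9000 nM.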

Compound 4, half-maximal inhibitory concentration: 4400 nM
Compound 4: middle estimate off by 1.1-fold (0.04 log units), on the low side; the range from low to high includes it.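

In this assay, dipropylamino in place of piperidin-1-yl on the isopropyl core gives a 1.6-fold higher number from compound 3 to compound 4 (0.21 log units; within the scatter), and this step matches the one on the chloro core: the same change on two cores in this assay, a 1.5-fold higher number (0.18 log units; within the scatter) from compound 1 to compound 2 and a 1.6-fold higher number (0.21 log units; within the scatter) from compound 3 to compound 4, 1.1-fold (0.04 log units) apart, within the scatter of two such steps. Isopropyl in place of chloro, read with dipropylamino on the chain, gives a 7.3-fold higher number from compound 2 to compound 4 (0.87 log units; beyond the scatter), and this step likewise matches its counterpart with piperidin-1-yl: the same change on two cores in this assay, a 6.8-fold higher number (0.83 log units; beyond the scatter) from compound 1 to compound 3 and a 7.3-fold higher number (0.87 log units; beyond the scatter) from compound 2 to compound 4, 1.1-fold (0.04 log units) apart, within the scatter of two such steps. Across these four compounds, each change therefore carries from one core to the other with no difference beyond the scatter, so the isopropyl step is the one that separates the compounds, while the amine step stays within the scatter on both cores; this rests on just two pairs per change in a single assay and does not show that either change would carry over in the same way to other cores in the series.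

On these data alone, it remains open whether morpholin-4-yl or dimethylamino in place of piperidin-1-yl, or a longer chain, would also leave the number within the scatter on both cores. As far as these compounds go, it is equally open whether fluoro or methoxy in place of chloro would give a step that carries across the amines as the isopropyl step does.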